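Esterifying the hydroxyethyl tail of a diaryl urea triazole

This account rests on a few compounds, and the source may have more. Where it says the series, first, only, none or still open, it means among the compounds named here.

Compound 1 `O=C(Nc1ccc(-n2cc(CCO[C@H]3O[C@@H](CO)[C@H](O)[C@@H]3O)nn2)cc1)Nc1ccccc1C(F)(F)F`: "not active" (no number reported)
Compound 2 `O=C(O)CCc1cn(-c2ccc(NC(=O)Nc3ccccc3C(F)(F)F)cc2)nn1`: "not determined" (no result reported)
Compound 3 `O=C(Nc1ccc(-n2cc(CCO)nn2)cc1)Nc1ccccc1C(F)(F)F`: 11200 nM

Among the measured compounds shown here, in an assay on isolated protein for inhibition of ATP-dependent RNA helicase DDX3X (Homo sapiens), read by FRET, with stated times of 30 s and 40 min (on this read-out higher numbers stand for weaker inhibition and lower numbers for stronger inhibition), compound 3 gives 11200 nM, the only number reported in this set. Compound 1 gives "not active" (no number reported) in this assay, and compound 2 gives "not determined" (no result reported), so neither offers a step against which to measure. Compound 4 `CC(C)CC(=O)OCCc1cn(-c2ccc(NC(=O)Nc3ccccc3C(F)(F)F)cc2)nn1` differs from compound 3 by isobutylcarbonyl in place of hydrogen on an oxygen on a saturated carbon. For the measured compounds named here, no measured pair shows this kind of change, so the expectation rests on compound 3 alone and on compound 1, which carries a larger substituent on that same oxygen and gives "not active" (no number reported). A step toward weaker inhibition is therefore expected, a 2.2-fold higher number from compound 3 to compound 4 (0.35 log units; beyond the scatter), beyond the usual scatter, and with a real chance of no number at all. Compound 4 is estimated at 25000 nM, within 6000 nM to 100000 nM.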

Compound 4, half-maximal inhibitory concentration: 400 nM
Compound 4: the middle estimate sits 63-fold (1.80 log units) above what was measured; the measured number lies below the stated range.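

In this assay, the oxygen of the 2-hydroxyethyl tail proves able to carry a substituent with a large gain, as isobutylcarbonyl in place of hydrogen gives a 28-fold lower number from compound 3 to compound 4 (1.45 log units; beyond the scatter) and the first clear sign of strong inhibition in this set. Substitution there does not always help, since compound 1 gives "not active" (no number reported) with a larger group on that same oxygen. Nothing available here accounts for the gain. On these data alone, whether it depends on the carbonyl or on the branched chain stays open. An acetyl group, a straight pentanoyl chain or an isobutyl ether on that oxygen would separate the two.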